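This account rests on a few compounds, and the source may have more. Where it says the series, first, only, none or still open, it means among the compounds named here.

Three compounds share one core and differ only in the groups on the outer aromatic ring. Compound 1 `COc1cc(/C=N/Nc2nc3ccccc3s2)cc(OC)c1O` gives 36% in a physicochemical assay on cells (Homo sapiens), with a stated time of 18 h, tested at 1 uM; a higher number here means a weaker effect of the compound at the concentration tested, a lower number a stronger effect. Compound 2 `COc1cc(/C=N/Nc2nc3ccccc3s2)cc(OC)c1OC` gives 100% in this assay. Compound 3 `Oc1ccc(/C=N/Nc2nc3ccccc3s2)cc1O` gives 44% in this assay, which places it second highest of the three; its number lies within the scatter of compound 1 and well below that of compound 2.

Compound 4 `COc1cc(/C=N/Nc2nc3ccccc3s2)ccc1O` is the compound not yet measured. Relative to compound 3 the change is methyl in place of hydrogen on an oxygen on an aromatic ring.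

One measured step shows the same kind of change: a number 64 percentage points higher from compound 1 to compound 2 (beyond the scatter). There the methyl removed the last remaining hydroxy group, and the effect was lost almost entirely. Compound 4 differs in that one hydroxy group stays in place, so it ends up carrying one hydroxy and one methoxy, as compound 1 does. On that basis a moderate weakening is expected rather than a complete loss, with compound 4 expected to land somewhere between compound 1 and compound 3 on one side and compound 2 on the other, giving an estimated step of a number 8 percentage points higher from compound 3 to compound 4 (within the scatter).

The estimate for compound 4 in this assay is therefore 52%, with a range from 30% to 80%.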

Compound 4, a percentage reported as activity, at one concentration (the size of the read-out at that concentration, not a potency): 65%
Compound 4: the middle estimate sits 13 percentage points below what was measured, within the range that was stated.
By their numbers in this assay, from the lowest: compounds 1 and 3 (each within the scatter of the next); then compound 4; then compound 2.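

In this assay, methyl on the oxygen weakens the effect even when a hydroxy group stays on the ring, as shown by a number 21 percentage points higher from compound 3 to compound 4 (beyond the scatter). So the loss does not depend on removing the last hydroxy, although this modest step is smaller than the large one seen when no hydroxy remained in compound 2. Compound 4 also isolates a second change, hydrogen in place of methoxy on an aromatic carbon, which gives a number 29 percentage points higher from compound 1 to compound 4 (beyond the scatter), so in this pair the methoxy that compound 1 carries and compound 4 lacks goes with a stronger effect. No measurement shown here explains either step.

The compounds shown leave open whether the weakening is specific to methyl or would also follow from a longer chain on that oxygen, such as ethyl. They also do not tell how the effect would change if an amine or a carboxylic acid took the place of the hydroxy group.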